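Ester variation and microsomal stability in the shared core

The source may report more compounds than this note shows. Statements on the series, on what has been measured and on what is new or still open speak of the compounds shown alone.

Measured compounds:
compound 1 `CCCCc1nc(C(C)C)c(CC(=O)OC)c(=O)n1Cc1ccc(-c2ccccc2-c2noc(=O)[nH]2)cc1`: 10.5%
compound 2 `CCCCc1nc(C(C)C)c(CC(=O)OCC(C)C)c(=O)n1Cc1ccc(-c2ccccc2-c2noc(=O)[nH]2)cc1`: 8.8%

In an ADME assay on microsomes from liver (Homo sapiens) for metabolic stability, with a stated time of 30 min (on this read-out higher numbers stand for a more stable compound and lower numbers for a less stable compound), compound 1 gives 10.5% and compound 2 gives 8.8%. Among the measured compounds shown here, the two numbers lie within the scatter of each other, so compound 2 is not separated from compound 1 on this read-out; the one step recorded so far, a number 1.7 percentage points lower from compound 1 to compound 2 (within the scatter), changed isopropyl for hydrogen on a saturated chain carbon bound to an oxygen next to a carbonyl group without moving the number beyond the scatter.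

Compound 3 `CCCCc1nc(C(C)C)c(CC(=O)OC2CCCCC2)c(=O)n1Cc1ccc(-c2ccccc2-c2noc(=O)[nH]2)cc1` continues at the same place: cyclohexyl in place of isobutyl on an oxygen next to a carbonyl group. For the measured compounds named here, the only measured step that bears on it is the one from compound 1 to compound 2, which also varied the group on this oxygen and stayed within the scatter. On that basis no step beyond the scatter is expected in this assay, a number 0.8 percentage points lower from compound 2 to compound 3 (within the scatter). For compound 3 in this assay the expected value is 8%, with a range from 2% to 18%.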

Compound 3, percent of the compound remaining: 13.3%
The estimate for compound 3 lay 5.3 percentage points below the measured number, and the stated range covers the measured number.
By their numbers in this assay, from the lowest: compounds 2, 1 and 3 (each within the scatter of the next).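

In this assay, among the compounds shown here, the exchange for cyclohexyl brings a six-membered non-aromatic ring of carbon only onto the oxygen next to a carbonyl group, where the earlier compounds carried only open chains, and the result is a number 4.5 percentage points higher from compound 2 to compound 3 (within the scatter) and a number 2.8 percentage points higher from compound 1 to compound 3 (within the scatter) when read against the methyl group. Across compounds 1, 2 and 3, then, methyl, isobutyl and cyclohexyl on this oxygen are not separated from one another, so neither the larger group nor the ring shows a step beyond the scatter at this place in these three compounds. Nothing available explains this outcome or ties it to any property of the groups.

Still open is whether a group on this oxygen that carries an amine, a hydroxyl or a phenyl ring would give a step beyond the scatter, as the three groups shown are all made of carbon only. Also open, from the compounds shown here alone, is how an amide or a carboxylic acid in place of the ester would read here, and whether changes elsewhere in the shared core would move the number at all.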